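Amino in Place of Chloro on the Core of Compound 2

The compounds below may be only part of what the source reports. "The series", "measured", "known", "first", "only" and "open" are said of these compounds alone.

Three compounds share a fused two-ring core carrying a benzyl group with a chloromethyl arm, and all three have been tested in a functional assay on LOX IMVI cells (Homo sapiens) for cytotoxicity, read by sulforhodamine B assay, with a stated time of 48 h; a lower number here means a stronger inhibitor of growth, a higher number a weaker inhibitor of growth. Compound 1 `ClCc1ccc(Cn2cnc3c(Cl)ncnc32)cc1` gives 3460 nM in this assay. Compound 3 `ClCc1cccc(Cn2cnc3c(Cl)ncnc32)c1` gives 5010 nM. Compound 2 `ClCc1ccccc1Cn1cnc2c(Cl)nc(Cl)nc21`, which carries a second chloro on the core, gives 360 nM, the lowest of the three numbers; its gap to compound 1 and its gap to compound 3 both lie beyond the usual scatter, so compound 2 is the strongest inhibitor of growth among these three.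

Compound 4 `Nc1nc(Cl)c2ncn(Cc3ccccc3CCl)c2n1` has not yet been measured. It differs from compound 2 in one place: amino in place of chloro on an aromatic carbon, on an aromatic carbon of a six-membered aromatic ring with two nitrogen, between two ring nitrogen atoms, meta to a chloro group. Within the data shown here, no measured pair in this set isolates that change, so the size of the step is open. The author expects a modest rise in the number, most likely beyond the scatter but not large. The rest of compound 2 is kept intact in compound 4. The step from compound 2 to compound 4 is estimated as a 2.5-fold higher number from compound 2 to compound 4 (0.40 log units; beyond the scatter). Compound 4 is expected to give about 900 nM in this assay, within a range from 300 nM to 3000 nM.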

Compound 4, concentration for total growth inhibition: 21900 nM
Compound 4: the middle estimate sits 24-fold (1.39 log units) below what was measured; the whole stated range lies below it.
By their numbers in this assay, from the lowest: compound 2; then compounds 1 and 3 (each within the scatter of the next); then compound 4.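

Among these compounds, the single change on the core of compound 2, amino in place of chloro on an aromatic carbon between two ring nitrogen atoms, gives a 61-fold higher number from compound 2 to compound 4 (1.78 log units; beyond the scatter) in this assay, a large step beyond the scatter. Among the compounds shown here, this is the first view of this position on its own, since no earlier pair differed in one place, and it shows that the number is highly sensitive to what sits on this carbon, even though one heavy atom simply replaces another, with 1 hydrogen-bond donor and 1 hydrogen-bond acceptor entering. For the compounds shown here, nothing measured here explains why the swap moves the number so far.

As far as these compounds go, it remains open whether a plain hydrogen, a methyl, a methoxy or a methylamino group on this carbon would stay close to compound 2 or shift as far as compound 4, which would show whether the loss is particular to the amino group or follows from removing the chloro. Also open, from the compounds shown here alone, is whether a step of this size would recur on the same core with the chloromethyl arm placed as in compound 1 or compound 3, or with the remaining chloro group replaced by an amine.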